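The compounds below may be only part of what the source reports. "The series", "measured", "known", "first", "only" and "open" are said of these compounds alone.

Of the compounds shown here, three from this series have been tested in a functional assay on DU-145 cells (Homo sapiens) for cytotoxicity, read by sulforhodamine B assay, with a stated time of 2 days, tested at 100 uM (on this read-out lower numbers stand for less inhibition and higher numbers for more inhibition at the one concentration tested (going by the name of the read-out)), and a fourth awaits its measurement.

Compound 1, `O=C(Nn1c(-c2cccc([N+](=O)[O-])c2)nc2c(-c3ccco3)n[nH]c2c1=O)c1cccnc1`, gives 1.66% in this assay. Compound 2, `COc1cccc(-c2nc3c(-c4ccco4)n[nH]c3c(=O)n2NC(=O)c2cccnc2)c1`, differs from it by one change: methoxy in place of nitro on an aromatic carbon. In this assay compound 2 gives 30.1%, so the step is a number 28.4 percentage points higher from compound 1 to compound 2 (beyond the scatter).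

Compound 3, `O=C(Nn1c(-c2cccc([N+](=O)[O-])c2)nc2c(-c3ccc(Cl)cc3)n[nH]c2c1=O)c1ccccc1`, sits on a different core; how its core differs from that of compound 1 is not broken down here. In this assay compound 3 gives 94.3%, the highest of the three numbers, well beyond the scatter from the other two.

Compound 4, `COc1cccc(-c2nc3c(-c4ccc(Cl)cc4)n[nH]c3c(=O)n2NC(=O)c2ccccc2)c1`, is related to compound 3 by the same change that turns compound 1 into compound 2: methoxy in place of nitro on an aromatic carbon. The place of the change reads the same in both pairs, so it is the same change, made once on each core.

Because the step of a number 28.4 percentage points higher from compound 1 to compound 2 (beyond the scatter) raised the number on the first core, the same change on the core of compound 3 is expected to leave compound 4 at a high value as well; since compound 3 already stands near the top of what a percentage of inhibition can show, the expected step of a number 9.3 percentage points lower from compound 3 to compound 4 (within the scatter) is small. Among the compounds with values here, compound 4 is therefore estimated at 85%, within a range from 55% to 100%, resting on only one earlier instance of the change and so held loosely.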

Compound 4, a percentage reported as inhibition, at one concentration (the size of the read-out at that concentration, not a potency): 94.1%
Compound 4: middle estimate off by 9.1 percentage points, on the low side; the range from low to high includes it.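

On the core of compound 3, going from 3-nitrophenyl to 3-methoxyphenyl comes with a number 0.2 percentage points lower from compound 3 to compound 4 (within the scatter) in this assay, so on this core the read-out does not separate the two compounds. The change therefore does not carry the same size of step from one core to the other, and a step seen on one core would have been a poor guide to its size on the other: the same change on two cores in this assay, a number 28.4 percentage points higher (beyond the scatter) from compound 1 to compound 2 and a number 0.2 percentage points lower (within the scatter) from compound 3 to compound 4, 28.6 percentage points apart, beyond the scatter of two such steps

Within the data shown here, this does not show which part of the cores accounts for the gap, since the two cores differ from each other in more than one place, and with only two cores no general rule can be drawn. It also leaves a caution about the scale, as compound 3 gives 94.3% and compound 4 gives 94.1%, both close to the top of what a percentage of inhibition can show at a single concentration, where any further gain would have little room to appear.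

The compounds shown carry only nitro or methoxy at this place, so how an amine or a carboxylic acid there would read in this assay stays open. Also open, going by these compounds, is whether the change would behave on a third core as it does on either of these two.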